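Trimming the Side Chain of a Protected Sugar Scaffold

A few compounds are considered here, and "the series" means these few. Any claim that something is new, unique, unknown or untested is made for them only; others in the source may bear on it.

Measured compounds:
compound 1 `O[C@@H]1[C@@H](OCc2ccccc2)[C@H](OCc2ccccc2)[C@@H](COCc2ccccc2)O[C@H]1CC1CCCCC1` — 4100 nM
compound 2 `OCCC[C@@H]1O[C@H](COCc2ccccc2)[C@@H](OCc2ccccc2)[C@H](OCc2ccccc2)[C@H]1O` — 19300 nM

Compound 1 and compound 2 share a benzyl-protected sugar core and were tested in a functional assay on HL-60 cells (Homo sapiens) for antiproliferative activity, read by MTT assay; a lower number here means a stronger inhibitor, a higher number a weaker inhibitor. For the measured compounds named here, compound 2 gives 19300 nM, the higher of the two numbers, and so is the weaker of this pair; the one step available, a 4.7-fold higher number from compound 1 to compound 2 (0.67 log units; beyond the scatter), shows that swapping the cyclohexyl for a 2-hydroxyethyl group cost potency.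

Compound 3 `O[C@H]1CO[C@H](COCc2ccccc2)[C@@H](OCc2ccccc2)[C@@H]1OCc1ccccc1` takes the pruning one stage further: hydrogen in place of 3-hydroxypropyl on a saturated ring carbon. Going by the values given here, no measured step covers removal of the whole chain, so the single step from compound 1 to compound 2 is the only guide, and it points to a modest loss when the side chain is made smaller. A small further weakening is therefore expected, a 1.7-fold higher number from compound 2 to compound 3 (0.22 log units; within the scatter), though the step could stay within the scatter. Compound 3 is estimated at 32000 nM, with a range from 10000 nM to 100000 nM.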

Compound 3, half-maximal inhibitory concentration: "not active" (no number reported)
For compound 3 the study gives words and no number; the estimate stays without a comparison.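

In this assay, for the compounds shown here, compound 3 is reported in words only, as not active, so no step from compound 2 to compound 3 can be read. Nothing shown offers an explanation for this result. The compounds shown leave open how large the change is when hydrogen replaces 3-hydroxypropyl.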